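This account rests on a few compounds, and the source may have more. Where it says the series, first, only, none or still open, it means among the compounds named here.

Working notes on the series. Going by the values given here, compound 1 `COc1nc(C2CCCCC2)ccc1[C@@H](c1ccccc1)[C@@](O)(CCN(C)C)c1cccc2ccccc12` in a toxicity assay on Vero cells (Chlorocebus sabaeus) for cytotoxicity (a higher number here means that more compound is tolerated, a lower number that less compound is tolerated), gives 32.3 ug/mL, the only plain number among the three measured values. Compound 2 `COc1ncc(-c2ccccc2)cc1[C@@H](c1ccccc1)[C@@](O)(CCN(C)C)c1cc(F)cc(F)c1` in this assay reaches only the limit > 50 ug/mL. Compound 3 `COc1ncc(-c2ccccc2)cc1[C@@H](c1ccccc1)[C@@](O)(CCN(C)C)c1ccccc1` likewise sits at the limit > 50 ug/mL. Compounds 2 and 3 differ by a phenyl in place of 3,5-difluorophenyl on a saturated chain carbon bound to an oxygen on a saturated carbon and two saturated chain carbons. Both values rest at the limit of > 50 ug/mL in this assay, at which 2 of the 3 values shown sit, so a step that the two limits leave unreadable from compound 2 to compound 3 stays unsized. Compound 1 therefore stands alone as the one readable point in this assay.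

Compound 4 `COc1nc(-c2ccc(OC(F)(F)F)cc2)ccc1[C@@H](c1ccccc1)[C@@](O)(CCN(C)C)c1cccc2ccccc12` differs from compound 1 by 4-(trifluoromethoxy)phenyl in place of cyclohexyl on an aromatic carbon. Among the compounds with values here, none of the measured pairs touches this position, and the single measured step in the set is unreadable, so no measured change bears on this exchange. The step of a 1.2-fold lower number from compound 1 to compound 4 (0.06 log units; within the scatter) is expected to remain within the scatter of this assay, with the direction left open. Compound 4 is estimated at 28 ug/mL, within 12 ug/mL to 60 ug/mL.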

Compound 4, half-maximal cytotoxic concentration: > 50 ug/mL
Compound 4: only a limit was reported; the forecaster's own chance of this, stated with the estimate: 20%; at least 1.7-fold (0.25 log units) between middle value and limit.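

The exchange of cyclohexyl for 4-(trifluoromethoxy)phenyl, on an aromatic carbon next to the ring nitrogen, gives an at least 1.5-fold higher number from compound 1 to compound 4 (0.18 log units; that floor lies within the scatter) in this assay and so shows that this position takes a larger aromatic group with no fall in the number, though no real rise is established. For compound 4 the value > 50 ug/mL is a limit and not a number. Going by these compounds alone, compound 4 thereby leaves compound 1 as the only plain number: the limit of > 50 ug/mL in this assay, at which 3 of the 4 values shown sit.

On these data alone, how far compound 4 lies past its limit stays open, and the step between compound 2 and compound 3 likewise cannot be read. Also open, as far as these compounds go, is whether an amine or a carboxylic acid on the phenyl ring at this position would bring the number back into the readable range.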